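A few compounds are considered here, and "the series" means these few. Any claim that something is new, unique, unknown or untested is made for them only; others in the source may bear on it.

Measured so far:
- compound 1 `O=[N+]([O-])c1cccc(NS(=O)(=O)c2ccc3nc(-c4ccccc4)c(-c4ccccc4)nc3c2)c1` — 85.6%
- compound 2 `O=S(=O)(Nc1cccc2ccccc12)c1ccc2nc(-c3ccccc3)c(-c3ccccc3)nc2c1` — 100%

In an ADME assay on the whole organism for pharmacokinetics, with Homo sapiens as the target (a lower number here means that a smaller share of the oral dose reaches the circulation, a higher number that a larger share of the oral dose reaches the circulation), compound 1 gives 85.6% and compound 2 gives 100%. Within the data shown here, the one step between them, a number 14.4 percentage points higher from compound 1 to compound 2 (beyond the scatter), came with naphthalen-1-yl in place of 3-nitrophenyl on the sulfonamide nitrogen. Compound 2 stands highest of the two numbers; its nearest neighbour is compound 1, lower by a margin beyond the scatter.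

Compound 3 `O=S(=O)(Nc1ccc(Cl)cc1)c1ccc2nc(-c3ccccc3)c(-c3ccccc3)nc2c1` is the next member, differing from compound 2 as 4-chlorophenyl in place of naphthalen-1-yl on a sulfonamide nitrogen. Among the measured compounds shown here, the only measured step that bears on this change is the swap of the aryl group on the sulfonamide nitrogen, a number 14.4 percentage points higher from compound 1 to compound 2 (beyond the scatter), which was modest and ran toward the two-ring group. Compound 3 returns to a single six-membered ring, so a step back in the other direction, of similar or smaller size, is expected; a rise beyond compound 2 cannot occur in this read-out. The expected step is a number 10 percentage points lower from compound 2 to compound 3 (within the scatter). Compound 3 is estimated at 90%, with a range from 78% to 100%.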

Compound 3, oral bioavailability: 100%
The estimate for compound 3 lay 10 percentage points below the measured number; measured number inside the range.
By their numbers in this assay, from the lowest: compound 1; then compounds 2 and 3 (each within the scatter of the next).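

In this assay the two-ring naphthalen-1-yl group on the sulfonamide nitrogen proves dispensable, since 4-chlorophenyl, with one six-membered aromatic ring of carbon only, gives no change at the digits printed from compound 2 to compound 3 (within the scatter) and the two compounds cannot be told apart in this read-out. The earlier rise therefore cannot be tied to the number of rings: the step of a number 14.4 percentage points higher from compound 1 to compound 3 (beyond the scatter) is the same in size as the step of a number 14.4 percentage points higher from compound 1 to compound 2 (beyond the scatter) and involves a one-ring group, so compound 3 goes against any reading that credits the second ring. Among the three compounds, only compound 1, with 3-nitrophenyl, stands apart from the other two, and no measurement here offers a reason for this pattern or for the lack of a difference between compound 2 and compound 3.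

Three aryl groups on one nitrogen cannot show whether the gap for compound 1 belongs to the nitro group itself or to 3-nitrophenyl as a whole. On these data alone, how the number would respond to a non-aryl group on the sulfonamide nitrogen, such as a longer alkyl chain, or to an amine or a carboxylic acid on the aryl ring, remains open.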